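Adding an Isobutyl Group to an Inactive Amide

The source may hold more compounds than are shown below. What is called first, only, known or untested is meant among the compounds shown, and "the series" means these compounds.

Compound 1 `CCC1C(=O)N(C)c2cnc(-n3ccc4cc(C(N)=O)ccc43)nc2N1c1ccn(C)n1` is a fused bicyclic amide that in a functional assay on NCI-H1975 cells (Homo sapiens) for antiproliferative activity, read by CCK-8 assay, with a stated time of 72 h (on this read-out lower numbers stand for stronger inhibition of growth and higher numbers for weaker inhibition of growth), gives "not active" (no number reported), so no single number stands for it. Compound 3 `CCC1C(=O)N(C)c2cnc(Nc3ccc(S(=O)(=O)NCCO)cc3)nc2N1c1ccn(C)n1`, with a different side group on the shared core, likewise gives "not active" (no number reported) in this assay. Only compound 2 `CC[C@@H]1C(=O)N(C)c2cnc(Nc3ccc(S(N)(=O)=O)cc3)nc2N1C1CCCC1`, carrying yet another side group and a different ring on the core nitrogen, gives a measured result of 5290 nM in this assay. Compound 4 `CCC1C(=O)N(C)c2cnc(-n3ccc4cc(C(=O)NCC(C)C)ccc43)nc2N1c1ccn(C)n1` differs from compound 1 by isobutyl in place of hydrogen on an amide-type nitrogen. With nothing to measure in compound 1, the size of the step cannot be known; a weak result is expected, and a further "not active" reading is quite possible. Compound 4 is estimated at 8000 nM, within 2000 nM to 30000 nM.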

Compound 4, concentration for 50% growth inhibition: 10200 nM
For compound 4 the middle estimate is 1.3-fold (0.11 log units) below the measured one; the measured number falls inside the stated range.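

Within the data shown here, compound 1 has no number to compare, so no step from it to compound 4 can be read. On these data alone, how much the isobutyl group changes growth inhibition stays open. No measured evidence bears on this result.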